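Replacing a fluorophenyl with a methoxyphenyl in a diacylhydrazine

The source may report more compounds than this note shows. Statements on the series, on what has been measured and on what is new or still open speak of the compounds shown alone.

Measured so far:
compound 1, `CC(C)(C)N(NC(=O)c1ccccc1)C(=O)c1ccccc1Br`, 170 nM
compound 2, `CCc1ccccc1C(=O)N(NC(=O)c1ccccc1)C(C)(C)C`, 589 nM
compound 3, `CC(C)(C)N(NC(=O)c1cccc(F)c1)C(=O)c1ccccc1Cl`, 69.2 nM

All three share one core and were tested in an assay on cells for agonist activity at ecdysone receptor (Bombyx mori), read by a luciferase reporter, with a stated time of 24 h; a higher number here means that more compound is needed for the effect, a lower number that less compound is needed. Compound 3 stands lowest of the three numbers, so it needs the least compound; compound 1 is nearest, and compound 2 is furthest away. For the measured compounds named here, the only measured change at a single place, a 3.5-fold higher number from compound 1 to compound 2 (0.54 log units; beyond the scatter), concerns the ring on the carbonyl carbon next to the nitrogen that carries the tert-butyl group, not the ring that changes here.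

Compound 4, `COc1ccc(C(=O)NN(C(=O)c2ccccc2Cl)C(C)(C)C)cc1`, differs from compound 3 by 4-methoxyphenyl in place of 3-fluorophenyl on a carbonyl carbon. Going by the values given here, no measured step touches this ring, so the step from compound 3 to compound 4 cannot be read off from the data and is set here as small, in either direction, within or just beyond the scatter. In this assay compound 4 is therefore expected to give 50 nM, with a range from 15 nM to 200 nM, a step estimated at a 1.4-fold lower number from compound 3 to compound 4 (0.14 log units; within the scatter).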

Compound 4, half-maximal effective concentration: 51.3 nM
Compound 4: middle estimate off by 1.0-fold (0.01 log units), on the low side, within the range that was stated.
By their numbers in this assay, from the lowest: compounds 4 and 3 (each within the scatter of the next); then compound 1; then compound 2.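

This is the only step among the compounds shown that touches this ring, and in this assay the change of 3-fluorophenyl to 4-methoxyphenyl on a carbonyl carbon gives a 1.3-fold lower number from compound 3 to compound 4 (0.13 log units; within the scatter), so compound 3 and compound 4 cannot be told apart. The exchange is not a trivial one on paper: the entering group has one more heavy atom than the group it replaces, swaps fluorine for oxygen and brings a hydrogen-bond acceptor that the leaving group lacks, yet the number stays within the scatter, so for this pair these differences in the ring leave the read-out unchanged. Nothing measured here explains why the two compounds match.

A single pair says nothing general about this ring, and since the group and its printed position change together, the contribution of each cannot be separated. From the compounds shown here alone, whether the same holds for quite different groups on this ring, such as an amine or a carboxylic acid, remains open, as does whether a longer chain in place of the methoxy group would leave the number where it is.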